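Cyanoguanidine dihydropyrimidine esters against the A3 receptor

The source may hold more compounds than are shown below. What is called first, only, known or untested is meant among the compounds shown, and "the series" means these compounds.

Measured so far:
compound 1, `CCOC(=O)C1=C(C)N/C(=N\C#N)NC1c1cccs1`: 3%
compound 2, `CC1=C(C(=O)OC(C)C)C(c2ccco2)N/C(=N/C#N)N1`: 4%

Both compounds share a core in which a cyanoguanidine is built into a six-membered ring that carries a methyl group, an ester and an aromatic five-membered ring. In an assay on HeLa cells for displacement of a labelled ligand from adenosine receptor A3 (Homo sapiens), with a stated time of 180 min, tested at 1 uM (a lower number here means less inhibition, a higher number more inhibition at the concentration tested (going by the name of the read-out)), compound 1 gives 3%, and compound 2 gives 4%. Compound 2 carries the top number of the two, but the gap to compound 1 lies within the scatter, so the two compounds are not told apart by this assay; both sit close to no inhibition at the concentration tested.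

Compound 3, `CC1=C(C(=O)OC(C)C)C(c2cccs2)N/C(=N/C#N)N1`, is the next compound. It differs from compound 2 by thiophen-2-yl in place of furan-2-yl on a saturated ring carbon. The change keeps the ring size and the count of hetero atoms the same, and compound 1 already shows that a thiophen-2-yl group on this core reads near the bottom of the scale, as its value 3% shows. No step beyond the scatter is expected here: the estimated step from compound 2 to compound 3 is no change at the digits printed from compound 2 to compound 3 (within the scatter), in no particular direction. Compound 3 is therefore expected to give about 4%, within -6% to 14%.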

Compound 3, a percentage reported as inhibition, at one concentration (the size of the read-out at that concentration, not a potency): 27%
For compound 3 the middle estimate is 23 percentage points below the measured one; the whole stated range lies below it.
By their numbers in this assay, from the lowest: compounds 1 and 2 (each within the scatter of the next); then compound 3.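

In this assay, thiophen-2-yl in place of furan-2-yl on the saturated ring carbon gives a number 23 percentage points higher from compound 2 to compound 3 (beyond the scatter), although the two groups match in heavy atom count, ring size and counted donors and acceptors; with an isopropoxycarbonyl group on the neighbouring ring atom, this position therefore separates a sulfur-containing ring from an oxygen-containing one. Thiophen-2-yl alone does not set the number, since methyl in place of hydrogen on the saturated chain carbon bound to the ester oxygen gives a number 24 percentage points higher from compound 1 to compound 3 (beyond the scatter), so the ester also matters when the thiophen-2-yl group is held fixed. Nothing available here accounts for either step.

The compounds shown do not tell whether the ring and ester changes depend on each other, as the furan-2-yl compound with the smaller ester is absent from this set. Also open, as far as these compounds go, is whether a phenyl ring at the saturated ring carbon, or a longer chain such as a butyl ester, would carry the number further, and what potency lies behind a read-out taken at one concentration.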